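Adding a Methyl to the Furan of Compound 2

A few compounds are considered here, and "the series" means these few. Any claim that something is new, unique, unknown or untested is made for them only; others in the source may bear on it.

Compound 2 `Nc1nc(-c2cccc(Cl)c2)cc(-c2ccco2)n1` gives 39.1 nM in an assay on membranes from brain (strain Sprague-Dawley) for displacement of a labelled ligand from adenosine receptor A1 (Rattus norvegicus), read by scintillation counting, with a stated time of 1 h; a lower number here means a stronger inhibitor, a higher number a weaker inhibitor. Going by the values given here, its only measured neighbour, compound 1 `Nc1nc(-c2ccccc2)cc(-c2cccc(Cl)c2)n1`, gives 22.8 nM in this assay. Among the compounds with values here, the single step between them, a 1.7-fold higher number from compound 1 to compound 2 (0.23 log units; within the scatter), replaces phenyl with furan-2-yl on an aromatic carbon, and since that step lies within the scatter, compound 2 stands alongside compound 1 on the two numbers known so far, with nothing to separate them.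

Compound 3 `Cc1ccc(-c2cc(-c3cccc(Cl)c3)nc(N)n2)o1` differs from compound 2 in one place: methyl in place of hydrogen on an aromatic carbon. Within the data shown here, no measured step bears directly on this change; the one step available, from compound 1 to compound 2, exchanges the whole ring rather than decorating it and was itself within the scatter. The data therefore give no reason to expect a step beyond the scatter in this assay in either direction, and compound 3 is expected to land near compound 2, the step of a 1.0-fold higher number from compound 2 to compound 3 (0.01 log units; within the scatter) being small. On that basis compound 3 is estimated at 40 nM, with a range from 15 nM to 110 nM.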

Compound 3, inhibition constant: 129 nM
Compound 3: the middle estimate sits 3.2-fold (0.51 log units) below what was measured, and the stated range ends below it.
By their numbers in this assay, from the lowest: compounds 1 and 2 (each within the scatter of the next); then compound 3.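

In this assay, going by these compounds alone, a single methyl on an aromatic carbon of the five-membered aromatic ring with 1 oxygen, next to the ring oxygen, gives a 3.3-fold higher number from compound 2 to compound 3 (0.52 log units; beyond the scatter) and so separates two compounds for the first time in this short series. Within the data shown here, this place on the furan therefore does not accept even this one added carbon without a measurable rise in the number, something the earlier compounds could not show, as they carried only hydrogen there. The exchange of phenyl for furan-2-yl alone stayed within the scatter, whereas 5-methylfuran-2-yl in place of phenyl gives a 5.7-fold higher number from compound 1 to compound 3 (0.75 log units; beyond the scatter) and moves the number well clear of it, and no measurement shown here explains the rise.

The compounds shown leave open whether the rise is particular to methyl or would also follow from another group at this place, such as ethyl, methoxy, an amine or a fluorine atom. They also leave open whether a methyl on another carbon of the furan, or on the phenyl ring of compound 1, would raise the number in the same way.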